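Methoxy for Trifluoromethyl on the Biaryl Sulfonamide

The source may hold more compounds than are shown below. What is called first, only, known or untested is meant among the compounds shown, and "the series" means these compounds.

Measured so far:
Compound 1 `Cc1cc(C)c(S(=O)(=O)N2CCN(C3CN4CCC3CC4)CC2)c(C)c1` gives 84 nM in a functional assay on DLD-1 cells (Homo sapiens) for antiproliferative activity, read by CellTiter-Glo, with a stated time of 72 h; a higher number here means a weaker inhibitor, a lower number a stronger inhibitor.
Compound 2 `CC1CCN(C2CCN(S(=O)(=O)c3ccccc3-c3ccc(C(F)(F)F)cc3)CC2)CC1` gives 122 nM in this assay.
Compound 3 `CC1CCN(C2CCN(S(=O)(=O)c3cccc4cnccc34)CC2)CC1` gives 225 nM in this assay.

Compound 2 carries a 4-(trifluoromethyl)phenyl on its aryl sulfonamide. Its number in this assay lies within the usual scatter of both compound 1 and compound 3, so the three measured compounds cannot be told apart on these data.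

Compound 4 `COc1ccc(-c2ccccc2S(=O)(=O)N2CCC(N3CCC(C)CC3)CC2)cc1` differs from compound 2 in one place: methoxy in place of trifluoromethyl on an aromatic carbon. Among the measured compounds shown here, no measured pair in this set shows what such an exchange does in this assay, so the expectation rests on the change itself and on the narrow spread of the three measured numbers. The expected step from compound 2 to compound 4 is small, a 1.5-fold higher number from compound 2 to compound 4 (0.17 log units; within the scatter), leaning slightly toward a weaker inhibitor but not clearly beyond the scatter.

Compound 4 is therefore estimated at 180 nM in this assay, with a range from 60 nM to 550 nM.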

Compound 4, half-maximal inhibitory concentration: 1000 nM
The estimate for compound 4 lay 5.6-fold (0.74 log units) below the measured number; the measured number lies above the stated range.
By their numbers in this assay, from the lowest: compounds 1, 2 and 3 (each within the scatter of the next, the first and the last beyond it); then compound 4.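

In this assay, methoxy in place of trifluoromethyl on this aromatic carbon, para to a large group, gives an 8.2-fold higher number from compound 2 to compound 4 (0.91 log units; beyond the scatter), so the group at this position clearly affects the read-out. The earlier compounds shown here included no pair differing in one place, so they could not show this, and here a single exchange on the 4-substituted phenyl moves the number beyond the scatter. Nothing available explains why this exchange weakens the compound.

With only these two groups shown at this carbon, it remains open whether the loss is specific to methoxy or would also appear with a hydrogen, a fluorine, a chlorine or a nitrile there. From the compounds shown here alone, it is also open whether the same exchange would cost as much on a different shared core.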